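This account rests on a few compounds, and the source may have more. Where it says the series, first, only, none or still open, it means among the compounds named here.

Compound 1 `CN(C)CCn1cnnc1-c1cc(Oc2ccc(NC(=O)N/N=C/c3c[nH]c4ccccc34)cc2F)ccn1` gives 820 nM in a functional assay on A549 cells (Homo sapiens) for cytotoxicity, read by MTT assay, with a stated time of 72 h; on this read-out higher numbers stand for weaker inhibition and lower numbers for stronger inhibition.
Compound 2 `Cn1ncnc1-c1cc(Oc2ccc(NC(=O)N/N=C/c3ccccc3)cc2F)ccn1` gives only a limit of this assay, > 100000 nM.

Among the measured compounds shown here, compound 1 holds the only number measured in this assay, and the other value is a limit, namely (the limit of > 100000 nM in this assay, at which 1 of the 2 values shown sits). Compound 3 `CN(C)CCn1cnnc1-c1cc(Oc2ccc(NC(=O)N/N=C/c3ccc(O)cc3O)cc2F)ccn1` has not yet been measured; it differs from compound 1 in one place: 2,4-dihydroxyphenyl in place of 1H-indol-3-yl on a carbon with a double bond to nitrogen. For the measured compounds named here, with no measured step joining two compounds here, the size of the change from compound 1 to compound 3 can only be expected, not read off. The expectation is a step toward weaker inhibition beyond the usual scatter, of about a 3.7-fold higher number from compound 1 to compound 3 (0.56 log units; beyond the scatter), with the number for compound 1, 820 nM, as the only anchor. Compound 3 is therefore estimated at 3000 nM in this assay, with a range from 800 nM to 20000 nM.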

Compound 3, half-maximal inhibitory concentration: 12700 nM
Compound 3: middle estimate off by 4.2-fold (0.63 log units), on the low side; the measured number falls inside the stated range.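

Swapping the group on a carbon with a double bond to nitrogen, with the rest of the molecule unchanged, gives a 15-fold higher number from compound 1 to compound 3 (1.19 log units; beyond the scatter) in this assay. Among the compounds shown here, this is the first direct reading of this position, and it shows that the position is not indifferent: 1H-indol-3-yl goes with clearly stronger inhibition than 2,4-dihydroxyphenyl. Nothing measured here explains why the step has this direction or size.

For the compounds shown here, the single step cannot separate the loss of the 1H-indol-3-yl group from the arrival of the two hydroxyl groups, so it remains open how a methoxyphenyl or an aminophenyl group would stand at this position. On these data alone, it also remains open whether the same swap would give a step of similar size on a core with a chain other than the one shared by these two compounds.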